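The source may report more compounds than this note shows. Statements on the series, on what has been measured and on what is new or still open speak of the compounds shown alone.

Measured in a physicochemical assay for lipophilicity, measured as octanol-water partition; a higher number here means a more lipophilic compound, a lower number a more polar compound:
- compound 1 `C[C@H](NC(=O)COc1cc(C(F)(F)F)c2c(-c3ccccn3)nn(C)c2n1)c1ccccc1`: 3.5
- compound 2 `Cc1nn(C)c(C)c1C(C)NC(=O)COc1cc(C(F)F)c2c(C3CC3)nn(C)c2n1`: 2.8
- compound 3 `Cc1cc2c(cn1)[C@@H](NC(=O)COc1cc(C)c3c(C4CC4)nn(C)c3n1)CC2`: 3.5

Of these three, compound 2 stands lowest at 2.8. Compound 1 and compound 3 share the same number, and each lies higher than compound 2 by a gap beyond the scatter.

The account now follows one change. Compound 4 `Cc1nn(C)c(C)c1C(C)NC(=O)COc1cc(C(F)F)c2c(-c3ccccc3)nn(C)c2n1` departs from compound 2 in a single place: phenyl in place of cyclopropyl on an aromatic carbon. This puts phenyl in place of cyclopropyl on an aromatic carbon. For the measured compounds named here, no pair of measured compounds differs in only one place, so the data offer no direct precedent for this step. Compound 1 and compound 3 differ from compound 2 in several places and set no size for it. The expectation therefore rests on the structural change alone, in which the entering group is the larger and neither group counts a hydrogen-bond donor or acceptor. An upward move beyond the scatter is expected, and the estimated size is a number 0.60 log units higher from compound 2 to compound 4 (beyond the scatter). In this assay the estimate for compound 4 is 3.4, with an expected range from 3 to 3.9.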

Compound 4, partition coefficient: 3.9
The estimate for compound 4 lay 0.50 log units below the measured number; measured number inside the range.
By their numbers in this assay, from the lowest: compound 2; then compounds 1 and 3 (each within the scatter of the next); then compound 4.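

For the compounds shown here, putting phenyl in place of cyclopropyl on this aromatic carbon of the five-membered ring gives, in this assay, a number 1.10 log units higher from compound 2 to compound 4 (beyond the scatter) and is the first single-place step in the set, so it gives this position a measured size that the earlier compounds could not. Both groups hold carbon only and count no hydrogen-bond donors or acceptors, so the large step comes with no change in those counts. Nothing measured here explains the size of the step.

From the compounds shown here alone, whether the same exchange would give a step of similar size in the core of compound 3, which also carries cyclopropyl, remains open. So does the outcome at this position for a group such as an amine, a carboxylic acid or a longer chain such as n-butyl.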